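The compounds below may be only part of what the source reports. "The series", "measured", "known", "first", "only" and "open" are said of these compounds alone.

Among the compounds with values here, in a physicochemical assay for solubility, read by HPLC, in phosphate buffer, measured as kinetic solubility, at pH 7.4 (a lower number here means a less soluble compound, a higher number a more soluble compound), compound 1 (`CCC(=O)c1cc(-c2ccc(S(N)(=O)=O)cc2)n(-c2ccc(Cl)cc2)n1`) gives 41900 nM and compound 2 (`CCC(=O)c1cc(-c2ccc(S(N)(=O)=O)cc2)n(-c2ccccc2)n1`) gives 47200 nM as the only two readings so far. These numbers lie within the scatter of each other, so compound 2 stands level with compound 1, with no order between them. Compound 3 (`CCC(=O)c1cc(-c2ccc(S(N)(=O)=O)cc2)n(-c2ccc(OC)cc2)n1`) is still unmeasured. Its difference from compound 2 is methoxy in place of hydrogen on an aromatic carbon in the form of methoxy in place of hydrogen on an aromatic carbon, para to a large group.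

Within the data shown here, one measured step bears on this change: hydrogen in place of chloro on an aromatic carbon gave a 1.1-fold higher number from compound 1 to compound 2 (0.05 log units; within the scatter) and stayed within the scatter. Among the measured compounds shown here, that step covers chloro only, and no measured compound carries methoxy, so it guides the expectation only loosely. No shift beyond the scatter is expected in this assay and no firm direction can be given. The estimated step of a 1.1-fold lower number from compound 2 to compound 3 (0.05 log units; within the scatter) is expected to stay within the scatter, with the range kept wide for the untested methoxy. For compound 3 the estimated value is 42000 nM with an expected range from 19000 nM to 85000 nM in this series.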

Compound 3, solubility: 64300 nM
For compound 3 the middle estimate is 1.5-fold (0.18 log units) below the measured one; low and high end bracket the measured number.
By their numbers in this assay, from the lowest: compounds 1, 2 and 3 (each within the scatter of the next).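

In this assay, methoxy now stands at the place para to a large group, where only hydrogen and chloro had been seen, and the change from phenyl to 4-methoxyphenyl gives a 1.4-fold higher number from compound 2 to compound 3 (0.13 log units; within the scatter). Methoxy in place of chloro on the same aromatic carbon gives a 1.5-fold higher number from compound 1 to compound 3 (0.19 log units; within the scatter), so the series now has a group with an oxygen at this position, and neither step involving it leaves the scatter: hydrogen, chloro and methoxy stand level here, with no order among them. Nothing on hand gives a reason for these readings.

Only these three groups are shown at this one place, so it remains open whether an amine, a carboxylic acid or a longer chain such as butoxy there would give a step beyond the scatter in this assay. As far as these compounds go, all three compounds share the rest of the core of compound 1, so what a change elsewhere would do, for example a carboxylic acid in place of the sulfonamide, is also open.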